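Changing the amide benzyl group on the methyl analogue

A few compounds are considered here, and "the series" means these few. Any claim that something is new, unique, unknown or untested is made for them only; others in the source may bear on it.

In a functional assay on A2780 cells (Homo sapiens) for antiproliferative activity, read by resazurin assay, with a stated time of 72 h (on this read-out higher numbers stand for weaker inhibition and lower numbers for stronger inhibition), compound 1 (`CN(Cc1ccccc1Br)C(=O)c1cc2c(Cc3cccc(Cl)c3)n[nH]c2cc1O`) gives 130 nM and compound 2 (`Cc1cccc(Cc2n[nH]c3cc(O)c(C(=O)N(C)Cc4ccccc4Br)cc23)c1`) gives 310 nM, so compound 2 holds the higher, weaker number of the two. Compound 3 (`Cc1cccc(Cc2n[nH]c3cc(O)c(C(=O)N(C)Cc4ccc(Cl)c(F)c4)cc23)c1`) keeps the methyl group of compound 2. Its change lies on a saturated chain carbon bound to an amide-type nitrogen, where 4-chloro-3-fluorophenyl stands in place of 2-bromophenyl: 4-chloro-3-fluorophenyl in place of 2-bromophenyl on a saturated chain carbon bound to an amide-type nitrogen.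

Among the measured compounds shown here, the only measured step is a 2.4-fold higher number from compound 1 to compound 2 (0.38 log units; beyond the scatter). It is modest and beyond the scatter, but it concerns methyl in place of chloro on an aromatic carbon, not the group that changes here. For the measured compounds named here, no measured pair varies this group, so the data give no direction. No step beyond the scatter is expected in this assay, although the uncertainty is wide. The expected step is a 1.1-fold higher number from compound 2 to compound 3 (0.05 log units; within the scatter). Compound 3 is estimated at 350 nM, with an expected range of 100 nM to 1200 nM.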

Compound 3, half-maximal inhibitory concentration: 930 nM
Compound 3: the middle estimate sits 2.7-fold (0.42 log units) below what was measured; measured number inside the range.
By their numbers in this assay, from the lowest: compound 1; then compound 2; then compound 3.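

The amide benzyl position, which the earlier pair left unchanged, responds to its aryl group in this assay: replacing 2-bromophenyl with 4-chloro-3-fluorophenyl on a saturated chain carbon bound to an amide-type nitrogen gives a 3.0-fold higher number from compound 2 to compound 3 (0.48 log units; beyond the scatter) and so weakens inhibition. This modest step beyond the scatter shows that the position is not neutral to the change and that the series can lose activity here as well as at the aromatic carbon behind a 2.4-fold higher number from compound 1 to compound 2 (0.38 log units; beyond the scatter), but a single pair cannot separate the loss of the 2-bromophenyl group from the entry of the 4-chloro-3-fluorophenyl group. Nothing in the available data explains the step.

The compounds shown leave open whether chloro in place of methyl on the aromatic carbon would give the same change with 4-chloro-3-fluorobenzyl on the amide as it does with 2-bromobenzyl. They also leave open how this position responds to a plain unsubstituted benzyl group, a pyridylmethyl group or a longer chain such as phenethyl.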